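Thiophene in place of pyridine at the alkyne carbon

This account rests on a few compounds, and the source may have more. Where it says the series, first, only, none or still open, it means among the compounds named here.

Compound 2 `O=C(O)CCc1ccc(C#Cc2ccncc2)cc1` gives 100% in an in vitro functional assay on 1321-N1 cells for agonist activity at Free fatty acid receptor 1 (Homo sapiens), read by fluorescence, spectrophotometry and calcium flux; a higher number here means a larger maximal response, a lower number a smaller maximal response. Compound 1 `O=C(O)CCc1ccc(C#Cc2ccnc(Oc3ccccc3)c2)cc1` gives 94% in this assay and compound 3 `Cc1cc(C#Cc2ccc(CCC(=O)O)cc2)ccn1` gives 102%; compound 2 sits among them, with a number 2 percentage points higher from compound 2 to compound 3 (within the scatter) and a number 6 percentage points higher from compound 1 to compound 2 (within the scatter) both within the scatter. Compound 4 `O=C(O)CCc1ccc(C#Cc2cccs2)cc1` differs from compound 2 by thiophen-2-yl in place of pyridin-4-yl on a triple-bonded carbon. Among the compounds with values here, no measured step touches this ring itself; the steps of a number 6 percentage points higher from compound 1 to compound 2 (within the scatter), a number 8 percentage points higher from compound 1 to compound 3 (within the scatter) and a number 2 percentage points higher from compound 2 to compound 3 (within the scatter) all concern substituents on the ring that leaves and all stay within the scatter, so the series so far shows no movement in maximal response at all. For compound 4 a step of a number 2 percentage points lower from compound 2 to compound 4 (within the scatter) within the scatter is therefore expected. Compound 4 is estimated at 98%, with a range from 85% to 110%.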

Compound 4, largest response reached (reported as efficacy), in percent of the reference or control that the assay uses: 97%
Beside the measured number, compound 4's estimate is 1 percentage points above it, within the range that was stated.
By their numbers in this assay, from the lowest: compounds 1, 4, 2 and 3 (each within the scatter of the next).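

In this assay, the exchange of the whole ring, thiophen-2-yl in place of pyridin-4-yl on a triple-bonded carbon, gives a number 3 percentage points lower from compound 2 to compound 4 (within the scatter). Unlike the earlier steps, which touch only substituents on the ring, this pair shows that the maximal response holds with a five-membered ring carrying sulfur and no ring nitrogen. No evidence on hand bears on this result.

Open, as far as these compounds go, is whether a saturated piperidin-4-yl ring or a plain phenyl ring on this carbon keeps the response. Also open, from the compounds shown here alone, is whether methyl or phenoxy on thiophen-2-yl leaves it within the scatter.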